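The compounds below may be only part of what the source reports. "The series", "measured", "known", "first", "only" and "open" are said of these compounds alone.

Values in a physicochemical assay for activation, with a stated time of 60 min; a higher number here means that more compound is needed for the effect, a lower number that less compound is needed:
compound 1 `NC(=O)N1C(=O)/C(=C(\O)c2ccc(Cl)s2)c2cc(Cl)ccc21`: 667000 nM
compound 2 `O=C1NC(=O)/C(=C\c2ccc(Cl)cc2)C2=C1CCCC2`: 500 nM

Of these two numbers, compound 2 holds the lower one at 500 nM, and the gap to compound 1 at 667000 nM lies well beyond the scatter. Within the data shown here, the pair differs in more than one place, so the series offers no measured step for a single change, and that gap says nothing about any one group.

Not yet measured is compound 3 `CCCCCc1ccc(/C=C2\C(=O)NC(=O)C3=C2CCCC3)cc1`, which keeps the core of compound 2 and carries pentyl in place of chloro on an aromatic carbon, para to a large group: pentyl in place of chloro on an aromatic carbon. Among the measured compounds shown here, with no measured precedent for this swap, the only anchor is compound 2 at 500 nM. For the measured compounds named here, no step clearly beyond the scatter is expected in this assay, with a slight lean towards a lower number and the direction left open. The expected change is a 1.3-fold lower number from compound 2 to compound 3 (0.10 log units; within the scatter). For compound 3 the estimated value is 400 nM, with an expected range of 60 nM to 3000 nM.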

Compound 3, half-maximal effective concentration: 9200 nM
Compound 3: middle estimate off by 23-fold (1.36 log units), on the low side; the measured number lies above the stated range.
By their numbers in this assay, from the lowest: compound 2; then compound 3; then compound 1.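

Among these compounds, this position on the aromatic ring, para to a large group, gives the first single change that can be read: in this assay, pentyl in place of chloro gives an 18-fold higher number from compound 2 to compound 3 (1.26 log units; beyond the scatter). The shared core stays the same across this pair, so the step belongs to this one exchange of chloro, a single chlorine atom, for pentyl, a chain of 5 carbon atoms, and the position is shown not to be indifferent to what it carries. No measurement of any property of either group accompanies this step, and its cause stays unassigned.

On these data alone, a single step cannot separate the removal of chloro from the addition of the chain, so it remains open whether a shorter chain such as methyl or ethyl would read nearer compound 2 or nearer compound 3. Also open, as far as these compounds go, is how an amine, a carboxylic acid or a methoxy group at the same place would read in this assay, and whether the step from chloro to pentyl would carry over to another core.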